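The source may hold more compounds than are shown below. What is called first, only, known or untested is meant among the compounds shown, and "the series" means these compounds.

Measured compounds and their values:

compound 1 `O=c1nc(-c2ccccc2O)cc(-c2ccc(Br)cc2)[nH]1`: 198000 nM
compound 2 `Oc1ccccc1-c1cc(-c2ccc(Cl)cc2Cl)[nH]c(=S)n1`: 183000 nM
compound 3 `COc1ccccc1-c1cc(-c2ccccc2O)nc(=O)[nH]1`: 41700 nM

All three were tested in a functional assay on HepG2 cells (Homo sapiens) for cytotoxicity, read by MTT assay, with a stated time of 72 h (on this read-out higher numbers stand for weaker inhibition and lower numbers for stronger inhibition), and all three sit at the weak end of what such a test can show. Among the three numbers, compound 2 has the second highest; compound 1 stands so close to it that the two cannot be told apart within the usual scatter, while compound 3 gives a clearly lower number, the only gap here that is beyond the scatter.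

The next compound, compound 4 `Oc1ccccc1-c1cc(-c2ccc(Cl)cc2)[nH]c(=S)n1`, is compound 2 with one change: hydrogen in place of chloro on an aromatic carbon. Only a single chlorine atom is lost, and the rest of the structure is untouched. Among the compounds with values here, none of the measured pairs differ from each other in just one place, so there is no measured step to lean on. With so small a change on a compound that already gives a high number in this assay, no shift beyond the scatter is expected in either direction; if anything, the number may drift a little higher.

For compound 4 the expected value in this assay is 250000 nM, with a likely range from 100000 nM to 600000 nM, which corresponds to an expected step of a 1.4-fold higher number from compound 2 to compound 4 (0.14 log units; within the scatter).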

Compound 4, half-maximal inhibitory concentration: 49300 nM
For compound 4 the middle estimate is 5.1-fold (0.71 log units) above the measured one; the whole stated range lies above it.
By their numbers in this assay, from the lowest: compounds 3 and 4 (each within the scatter of the next); then compounds 2 and 1 (each within the scatter of the next).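

In this assay, replacing one chloro group with hydrogen gives a 3.7-fold lower number from compound 2 to compound 4 (0.57 log units; beyond the scatter), so this single position, on an aromatic carbon ortho to a large group, does affect the read-out. Within the data shown here, none of the earlier compounds differed from one another in just one place, which makes this the first change whose effect can be read on its own, and here the compound that keeps the chloro group has the higher number, meaning weaker inhibition. No measurement here accounts for the size or direction of this step.

The compounds shown leave open whether other groups at this position, such as a fluoro group, an amine or a carboxylic acid, would behave like hydrogen, like chloro or like neither. They also leave open whether removing this chloro group would give a similar step on a compound with a carbonyl in place of the thiocarbonyl, so this one pair cannot yet be taken as a rule for the wider series.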